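The source may report more compounds than this note shows. Statements on the series, on what has been measured and on what is new or still open speak of the compounds shown alone.

Of the compounds shown here, two have been measured so far. Compound 1 `O=S(=O)(Nc1nnc(SCc2ccccc2)s1)c1ccccc1` is the parent, and compound 2 `Cc1ccc(S(=O)(=O)Nc2nnc(SCc3ccccc3)s2)cc1` carries a methyl in place of hydrogen on an aromatic carbon. In a toxicity assay on HaCaT cells (Homo sapiens) for cytotoxicity, tested at 125 uM (a higher number here means a weaker effect of the compound at the concentration tested, a lower number a stronger effect), compound 2 gives 83%, while compound 1 gives 84%; the step of a number 1 percentage points lower from compound 1 to compound 2 (within the scatter) is within the scatter, so the two compounds cannot be told apart on these numbers, and both leave most cells unaffected at the concentration tested.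

Compound 3 `COc1ccc(S(=O)(=O)Nc2nnc(SCc3ccccc3)s2)cc1` is not yet measured. It differs from compound 2 in one place: methoxy in place of methyl on an aromatic carbon. Within the data shown here, the only measured step that bears on this is the one from compound 1 to compound 2, which also changes a small group on that same aromatic carbon and was within the scatter. Among the measured compounds shown here, with only that step to go on, the expectation for compound 3 is a step of a number 1 percentage points lower from compound 2 to compound 3 (within the scatter) that stays within the scatter, in no clear direction. Compound 3 is therefore estimated at 82%, with a range from 68% to 96%.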

Compound 3, a percentage reported as activity, at one concentration (the size of the read-out at that concentration, not a potency): 79%
Beside the measured number, compound 3's estimate is 3 percentage points above it; low and high end bracket the measured number.
By their numbers in this assay, from the lowest: compounds 3, 2 and 1 (each within the scatter of the next).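

This result extends the picture at the position para to a large group: in this assay, the change from 4-methylphenyl to 4-methoxyphenyl gives a number 4 percentage points lower from compound 2 to compound 3 (within the scatter) and comparison with the unsubstituted parent gives a number 5 percentage points lower from compound 1 to compound 3 (within the scatter) so neither step separates the compounds. Methoxy differs from the earlier methyl in bringing an oxygen and a hydrogen-bond acceptor, and yet compounds 1, 2 and 3 cannot be told apart in this cell test, so hydrogen, methyl and methoxy are all tolerated here as far as these numbers can show. No measurement on hand offers an explanation for these numbers.

Still open, as far as these compounds go, is whether a group of a different kind on this same aromatic carbon, such as an amine, a carboxylic acid or a longer chain like butoxy, would give a number that stands clear of the scatter. The three compounds also say nothing about methoxy on any other carbon of this ring, or about changes to the rest of the shared core.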